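The compounds below may be only part of what the source reports. "The series", "measured", "known", "first", "only" and "open" are said of these compounds alone.

Series in a functional assay on HeLa cells (Homo sapiens) for inhibition, read by MTT assay, with a stated time of 48 h; on this read-out higher numbers stand for weaker inhibition of growth and lower numbers for stronger inhibition of growth:
- compound 1 `Cn1cc(C2CC(c3ccccc3)=NN2C(=O)c2cccnc2)c2cc(Br)ccc21`: 1730 nM
- compound 2 `Cn1cc(C2CC(c3ccc(F)cc3)=NN2C(=O)c2cccnc2)c2cc(Br)ccc21`: 630 nM
- compound 3 `Cn1cc(C2CC(c3ccc(Br)cc3)=NN2C(=O)c2cccnc2)c2cc(Br)ccc21`: > 10000 nM

Compound 3 gives no number, only a limit of this assay, at > 10000 nM.

Compound 4 `COc1ccc(C2=NN(C(=O)c3cccnc3)C(c3cn(C)c4ccc(Br)cc34)C2)cc1` has methoxy in place of bromo on an aromatic carbon, para to a large group, so 4-bromophenyl becomes 4-methoxyphenyl (methoxy in place of bromo on an aromatic carbon).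

Three measured steps change this same site. Bromo gave an at least 5.7-fold higher number from compound 1 to compound 3 (0.76 log units; beyond the scatter) and an at least 15-fold higher number from compound 2 to compound 3 (1.20 log units; beyond the scatter), while fluoro gave a 2.7-fold lower number from compound 1 to compound 2 (0.44 log units; beyond the scatter). So compounds 1 and 2, without bromo at this site, both give numbers under the limit. Going by the values given here, no compound with methoxy at this site has been measured, which leaves the size of the step uncertain. Loss of the bromo is nevertheless expected to move the number down, towards the values of compound 1 and compound 2, with a real chance of staying at the limit.

The expected step is an at least 4.0-fold lower number from compound 3 to compound 4 (0.60 log units; beyond the scatter). For compound 4 the estimated value is 2500 nM, with an expected range of 600 nM to 10000 nM.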

Compound 4, concentration for 50% growth inhibition: 890 nM
Compound 4: the middle estimate sits 2.8-fold (0.45 log units) above what was measured; the range from low to high includes it.
By their numbers in this assay, from the lowest: compounds 2, 4 and 1 (each within the scatter of the next, the first and the last beyond it). At a limit, above all of these: compound 3.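

In this assay, replacing the bromo of the 4-bromophenyl with methoxy at this carbon restores a measurable number: an at least 11-fold lower number from compound 3 to compound 4 (1.05 log units; beyond the scatter). The methoxy compound does not separate from the other two compounds without bromo, with a 1.4-fold higher number from compound 2 to compound 4 (0.15 log units; within the scatter) and a 1.9-fold lower number from compound 1 to compound 4 (0.29 log units; within the scatter), so among hydrogen, fluoro and methoxy a substituent at this carbon does not by itself push the number up to the limit, and only bromo goes with that limit. The value of compound 3 remains a limit, not a number: the limit of > 10000 nM in this assay, at which 1 of the 4 values shown sits.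

Going by these compounds, whether the loss seen with bromo extends to chloro or trifluoromethyl on this carbon remains open. On these data alone, how an amine or a hydroxyl at the same carbon would read in this assay also remains open.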